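This account rests on a few compounds, and the source may have more. Where it says the series, first, only, none or still open, it means among the compounds named here.

Measured so far:
compound 1, `COc1cc(C(=O)c2cn(-c3cccc(C)c3)cc2-c2ccccc2[N+](=O)[O-])cc(OC)c1OC`, gives 220 nM;
compound 2, `COc1cc(C(=O)c2cn(-c3cccc(C)c3)cc2-c2cccc([N+](=O)[O-])c2)cc(OC)c1OC`, gives 880 nM;
compound 3, `COc1cc(C(=O)c2cn(-c3cccc(N)c3)cc2-c2ccccc2[N+](=O)[O-])cc(OC)c1OC`, gives 14 nM.

All three were tested in a functional assay on MCF7 cells (Homo sapiens) for cytotoxicity, read by MTT assay, with a stated time of 96 h; on this read-out lower numbers stand for stronger inhibition and higher numbers for weaker inhibition. Compound 1 and compound 2 share a core and differ in one place: 3-nitrophenyl in place of 2-nitrophenyl on an aromatic carbon. That change made a 4.0-fold higher number from compound 1 to compound 2 (0.60 log units; beyond the scatter). Compound 3 differs from compound 1 in another place: amino in place of methyl on an aromatic carbon, and that change made a 16-fold lower number from compound 1 to compound 3 (1.20 log units; beyond the scatter). Among the three, compound 3 stands lowest, and its steps to compound 1 and compound 2 both lie beyond the scatter.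

Compound 4, `COc1cc(C(=O)c2cn(-c3cccc(N)c3)cc2-c2cccc([N+](=O)[O-])c2)cc(OC)c1OC`, has not yet been measured in this assay. It differs from compound 3 as compound 2 differs from compound 1: 3-nitrophenyl in place of 2-nitrophenyl on an aromatic carbon. This is the same kind of change, not the same: around the place, the ring atom two ring bonds away bears a 3-aminophenyl group in compound 3 and compound 4, where in compound 1 and compound 2 it bears a 3-methylphenyl group. Going by the values given here, only one earlier pair shows this change, so the expectation rests on a single step. Compound 4 is expected to show a 4.0-fold higher number from compound 3 to compound 4 (0.60 log units; beyond the scatter) because the same change gave a 4.0-fold higher number from compound 1 to compound 2 (0.60 log units; beyond the scatter). With that step, the expected value for compound 4 in this assay is 56 nM, likely falling between 25 nM and 150 nM.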

Compound 4, half-maximal inhibitory concentration: 510 nM
For compound 4 the middle estimate is 9.1-fold (0.96 log units) below the measured one, and the stated range ends below it.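

Exchanging 2-nitrophenyl for 3-nitrophenyl gave a higher number on both cores, but the size of the step did not carry over to the core bearing the 3-aminophenyl group, where it came to a 36-fold higher number from compound 3 to compound 4 (1.56 log units; beyond the scatter): the same change on two cores in this assay, a 4.0-fold higher number (0.60 log units; beyond the scatter) from compound 1 to compound 2 and a 36-fold higher number (1.56 log units; beyond the scatter) from compound 3 to compound 4, 9.1-fold (0.96 log units) apart, beyond the scatter of two such steps. Read the other way, amino in place of methyl gave a large step with the 2-nitrophenyl group, whereas with the 3-nitrophenyl group the step was a 1.7-fold lower number from compound 2 to compound 4 (0.24 log units; within the scatter), so the two changes did not act independently of each other in these compounds: the same change on two cores in this assay, a 16-fold lower number (1.20 log units; beyond the scatter) from compound 1 to compound 3 and a 1.7-fold lower number (0.24 log units; within the scatter) from compound 2 to compound 4, 9.1-fold (0.96 log units) apart, beyond the scatter of two such steps. This shows that in this assay the outcome of each change depended on the group present at the other place, but it does not show why, and a single pair on each core cannot tell how the change would behave on any further core.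

The compounds shown leave open whether this dependence would persist with a hydroxyl or a dimethylamino group in place of the amino group. They also leave open what a nitrile or a carboxylic acid in place of the nitro group would give on either core.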